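This account rests on a few compounds, and the source may have more. Where it says the series, first, only, none or still open, it means among the compounds named here.

In a functional assay on SK-BR-3 cells (Homo sapiens) for antiproliferative activity, read by MTT assay, with a stated time of 72 h (a lower number here means a stronger inhibitor, a higher number a weaker inhibitor), compound 1, `C/C=C1/[C@H](O[C@@H]2O[C@H](CO)[C@@H](O)[C@H](O)[C@H]2O)OC=C(C(=O)OC)[C@H]1CC(=O)OCc1ccco1`, sits at the limit of the assay and gives no number: > 15000 nM. That is where compound 1 stands on the numbers shown, with the limit of > 15000 nM in this assay, at which 2 of the 3 values shown sit, marking the edge beyond which nothing is resolved, so it cannot be ranked against a value that is a number. Compound 2, `C/C=C1/[C@H](O[C@@H]2O[C@H](COC(C)=O)[C@@H](OC(C)=O)[C@H](OC(C)=O)[C@H]2OC(C)=O)OC=C(C(=O)OC)[C@H]1CC(=O)OCCCCCCCCCCCCCCC`, gives 3810 nM in this assay, and that is a measured number. Compound 3, `C/C=C1/[C@H](O[C@@H]2O[C@H](COC(C)=O)[C@@H](OC(C)=O)[C@H](OC(C)=O)[C@H]2OC(C)=O)OC=C(C(=O)OC)[C@H]1CC(=O)SCCc1ccccc1`, stands at the limit as well, with > 15000 nM in this assay. Going by the values given here, no pair of measured compounds differs in only one place, so no measured step ties a single change to a size of effect.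

Compound 4, `C/C=C1/[C@H](O[C@@H]2O[C@H](CO)[C@@H](O)[C@H](O)[C@H]2O)OC=C(C(=O)OC)[C@H]1CC(=O)OCCc1ccc([N+](=O)[O-])cc1`, differs from compound 1 in one place: 4-nitrobenzyl in place of furan-2-yl on a saturated chain carbon bound to an oxygen next to a carbonyl group. Among the compounds with values here, no measured pair shows where such a change leads, and the only foothold is that compound 1 itself gives only a limit. The step of a number no higher from compound 1 to compound 4 (the limit leaves the size open) is therefore expected to be none beyond the scatter, with compound 4 expected most likely to remain at the limit. On that basis compound 4 is estimated at 15000 nM in this assay, with a range from 5000 nM to 50000 nM.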

Compound 4, half-maximal inhibitory concentration: > 20000 nM
Compound 4: only a limit was reported; the forecaster's own chance of this, stated with the estimate: 65%; middle value at least 1.3-fold (0.12 log units) from the limit.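

Compound 1 and compound 4 each give only a limit in this assay, so the step between them cannot be read, and the change from furan-2-yl to 4-nitrobenzyl has no size here. The compounds shown leave open whether that change alters the read-out at all, and where either compound would stand on a measured number.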